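Swapping a Nitrophenyl for a Fluorophenyl Amide Chain

The source may hold more compounds than are shown below. What is called first, only, known or untested is meant among the compounds shown, and "the series" means these compounds.

Measured so far:
Compound 1, `CCOC(=O)C1=Cc2ccccc2OC1(OCc1cn(CC(=O)Nc2ccc(OC)cc2)nn1)C(F)(F)F`: in a functional assay on A549 cells (Homo sapiens) for inhibition, read by MTT assay, with a stated time of 24 h (on this read-out higher numbers stand for weaker inhibition and lower numbers for stronger inhibition), compound 1 gives 29400 nM.
Compound 2, `CCOC(=O)C1=Cc2ccccc2OC1(OCc1cn(-c2ccc([N+](=O)[O-])cc2)nn1)C(F)(F)F`: in this assay compound 2 gives > 150000 nM, which is a limit of the assay and not a number.

Compound 2 therefore stands at the limit of > 150000 nM in this assay, at which 1 of the 2 values shown sits. Among the measured compounds shown here, the one measured step, an at least 5.1-fold higher number from compound 1 to compound 2 (0.70 log units; beyond the scatter), shows that exchanging the carbamoylmethyl chain for a nitrophenyl ring weakened inhibition.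

Compound 3, `CCOC(=O)C1=Cc2ccccc2OC1(OCc1cn(CC(=O)Nc2cccc(F)c2)nn1)C(F)(F)F`, reverses that kind of exchange: ((3-fluorophenyl)carbamoyl)methyl in place of 4-nitrophenyl on an aromatic nitrogen. For the measured compounds named here, the only evidence that bears on this is the step from compound 1 to compound 2, which was at least modest and went toward weaker inhibition; undoing it is expected to move the number downward by a comparable amount, bringing compound 3 near compound 1, whose value is 29400 nM. The step from compound 2 to compound 3 is estimated as an at least 5.0-fold lower number from compound 2 to compound 3 (0.69 log units; beyond the scatter). Compound 3 is estimated to give 30000 nM, with a likely range from 10000 nM to 120000 nM.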

Compound 3, half-maximal inhibitory concentration: > 150000 nM
Compound 3 was reported as a limit; the forecaster's own chance of this, stated with the estimate: 20%; middle value at least 5.0-fold (0.69 log units) away from the limit.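

The result shows that the amide chain on the aromatic nitrogen is not enough on its own to keep a measurable effect. With that chain kept, 3-fluorophenyl in place of 4-methoxyphenyl on an amide-type nitrogen gives an at least 5.1-fold higher number from compound 1 to compound 3 (0.70 log units; beyond the scatter), so the aryl group at the far end of the chain matters as well. Compound 2 and compound 3 both sit at a limit of the assay and not at a number, so the step between them cannot be read: the limit of > 150000 nM in this assay, at which 2 of the 3 values shown sit.

The compounds shown do not separate the loss of the methoxy group from the arrival of the fluorine, as both changes happen in one step. From the compounds shown here alone, how a plain phenyl, a 4-fluorophenyl or a 3-methoxyphenyl would behave at the end of this chain remains open.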